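A few compounds are considered here, and "the series" means these few. Any claim that something is new, unique, unknown or untested is made for them only; others in the source may bear on it.

In a functional assay on MGC-803 cells (Homo sapiens) for inhibition, read by MTT assay, with a stated time of 72 h (a higher number here means a weaker inhibitor, a lower number a stronger inhibitor), compound 1 (`FC(F)(F)c1ccc(CSc2nc(N3CCN(c4ncccn4)CC3)cc(C(F)(F)F)n2)cc1`) gives 35200 nM, compound 2 (`Cc1csc(Sc2cc(C(F)(F)F)nc(SCc3ccc(C(F)(F)F)cc3)n2)n1`) gives 21300 nM and compound 3 (`FC(F)(F)c1ccc(CSc2nc(Sc3ncccn3)cc(C(F)(F)F)n2)cc1`) gives 28600 nM. Compound 3 thus lies within the scatter of both others, and the three are not separated. Compound 4 (`Cc1nnc(Sc2cc(C(F)(F)F)nc(SCc3ccc(C(F)(F)F)cc3)n2)s1`) carries 5-methyl-1,3,4-thiadiazol-2-yl in place of pyrimidin-2-yl on a sulfur. Within the data shown here, the only measured exchange on that sulfur, a 1.3-fold higher number from compound 2 to compound 3 (0.13 log units; within the scatter), puts pyrimidin-2-yl in place of 4-methyl-1,3-thiazol-2-yl and stays within the scatter. No step beyond the scatter is therefore expected in this assay, and no direction is assigned. The estimate for compound 4 is 24000 nM, with an expected range of 11000 nM to 45000 nM. This estimate amounts to an expected 1.2-fold lower number from compound 3 to compound 4 (0.08 log units; within the scatter).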

Compound 4, half-maximal inhibitory concentration: 11400 nM
The estimate for compound 4 lay 2.1-fold (0.32 log units) above the measured number; measured number inside the range.
By their numbers in this assay, from the lowest: compounds 4, 2, 3 and 1 (each within the scatter of the next, the first and the last beyond it).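

Among these compounds, on a sulfur, the exchange in this assay now passes the scatter for the first time, with 5-methyl-1,3,4-thiadiazol-2-yl in place of pyrimidin-2-yl giving a 2.5-fold lower number from compound 3 to compound 4 (0.40 log units; beyond the scatter) as a modest step. Against 4-methyl-1,3-thiazol-2-yl, the same group gives a 1.9-fold lower number from compound 2 to compound 4 (0.27 log units; within the scatter) and stays within the scatter, so it is separated from pyrimidin-2-yl only. Nothing available accounts for this difference. Going by these compounds, whether the step depends on the methyl of 5-methyl-1,3,4-thiadiazol-2-yl remains open. So does how a longer alkyl chain or a carboxylic acid on that ring would read.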